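Swapping oxan-4-yl for 2-chloropyridin-3-yl on compound 3

The source may report more compounds than this note shows. Statements on the series, on what has been measured and on what is new or still open speak of the compounds shown alone.

In a functional assay on Shh Light II cells (Mus musculus) for inhibition, read by a luciferase reporter (a higher number here means a weaker inhibitor, a lower number a stronger inhibitor), compound 3 (`O=C(NC1CCOCC1)N1CCC(c2nc(-c3ccc4ccccc4n3)no2)CC1`) gives 480 nM against compound 2 (`CC(=O)N1CCC(NC(=O)N2CCC(c3nc(-c4ccc5ccccc5n4)no3)CC2)CC1`) at 500 nM and compound 1 (`O=C(CC1CCCCCC1)N1CCC(c2nc(-c3ccc4ccccc4n3)no2)CC1`) at 840 nM on the same core, all three within the scatter of one another.

Compound 4 (`O=C(Nc1cccnc1Cl)N1CCC(c2nc(-c3ccc4ccccc4n3)no2)CC1`) has 2-chloropyridin-3-yl in place of oxan-4-yl on an amide-type nitrogen. Among the measured compounds shown here, only one measured step changes the group at that place: a 1.0-fold lower number from compound 2 to compound 3 (0.02 log units; within the scatter) for oxan-4-yl in place of 1-acetylpiperidin-4-yl. The steps of a 1.7-fold lower number from compound 1 to compound 2 (0.23 log units; within the scatter) and a 1.8-fold lower number from compound 1 to compound 3 (0.24 log units; within the scatter) on a carbonyl carbon also stay within the scatter. None of these puts an aromatic ring on that nitrogen, so the present change has no direct measure and the range must stay wide.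

No shift beyond the scatter is expected, and the expected step is a 1.5-fold lower number from compound 3 to compound 4 (0.18 log units; within the scatter) on present evidence. The estimated value for compound 4 is 320 nM with an expected range from 80 nM to 1200 nM as a working figure.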

Compound 4, half-maximal inhibitory concentration: 1600 nM
Beside the measured number, compound 4's estimate is 5.0-fold (0.70 log units) below it; measured number above the stated range.
By their numbers in this assay, from the lowest: compounds 3, 2, 1 and 4 (each within the scatter of the next, the first and the last beyond it).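

In this assay the amide-type nitrogen is no longer a place where changes leave the number unmoved: 2-chloropyridin-3-yl in place of oxan-4-yl gives a 3.3-fold higher number from compound 3 to compound 4 (0.52 log units; beyond the scatter) and in place of 1-acetylpiperidin-4-yl gives a 3.2-fold higher number from compound 2 to compound 4 (0.51 log units; beyond the scatter) for this aromatic ring, while the two non-aromatic rings had stayed within the scatter of each other. Against the cycloheptylmethyl amide, the change on the carbonyl carbon gives a 1.9-fold higher number from compound 1 to compound 4 (0.28 log units; within the scatter) and so does not separate these two groups. Nothing measured here accounts for the higher number.

Open is whether the step follows the aromatic ring itself or the chlorine, since 2-chloropyridin-3-yl is the only aromatic group on this nitrogen among the compounds shown. Unsubstituted phenyl and pyridin-3-yl would separate those two readings, and a cyclohexyl group would test the non-aromatic side.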